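Notes on the hydroxyalkyl tail of compound 3 and compound 4

The compounds below may be only part of what the source reports. "The series", "measured", "known", "first", "only" and "open" are said of these compounds alone.

Measured so far in an ADME assay on SK-OV-3 cells (Homo sapiens) for cytotoxicity, read by sulforhodamine B assay, with a stated time of 48 h, tested at 10 uM; a lower number here means less inhibition, a higher number more inhibition at the concentration tested (going by the name of the read-out):
- compound 1 `CCCCCCCc1cn(C(c2ccccc2)c2cc3cc(Br)ccc3nc2OC)nn1` gives 10.5%
- compound 2 `COc1nc2ccc(Br)cc2cc1C(c1ccccc1)n1cc(-c2cccc(F)c2)nn1` gives 12.7%
- compound 3 `COc1nc2ccc(Br)cc2cc1C(c1ccccc1)n1cc(CCCO)nn1` gives 13.8%

Compound 3 has the highest of the three numbers, but the three values sit close together: the step of a number 1.1 percentage points higher from compound 2 to compound 3 (within the scatter) and the step of a number 3.3 percentage points higher from compound 1 to compound 3 (within the scatter) are both within the scatter, as is the step of a number 2.2 percentage points higher from compound 1 to compound 2 (within the scatter). Nothing in this set separates the three compounds in this assay.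

Compound 4 `COc1nc2ccc(Br)cc2cc1C(c1ccccc1)n1cc(CO)nn1` is not yet measured. Its difference from compound 3 is hydroxy in place of 2-hydroxyethyl on a saturated chain carbon bound to an aromatic carbon. The step that bears most directly on it is the earlier chain change at the same saturated chain carbon, a number 3.3 percentage points higher from compound 1 to compound 3 (within the scatter), which did not move the number beyond the scatter; the swap of the whole group on the aromatic carbon, a number 1.1 percentage points higher from compound 2 to compound 3 (within the scatter), was equally flat. Shortening the hydroxyalkyl chain is therefore expected to give a step of a number 0.8 percentage points lower from compound 3 to compound 4 (within the scatter), that is, none beyond the scatter. Compound 4 is estimated to give 13% in this assay, within a range of 5% to 22%.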

Compound 4, a percentage reported as inhibition, at one concentration (the size of the read-out at that concentration, not a potency): 3.23%
Compound 4: the middle estimate sits 9.8 percentage points above what was measured; measured number below the stated range.
By their numbers in this assay, from the lowest: compounds 4, 1, 2 and 3 (each within the scatter of the next, the first and the last beyond it).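

In this assay, for the compounds shown here, this is the first single change that moves the number beyond the scatter: hydroxy in place of 2-hydroxyethyl on a saturated chain carbon bound to an aromatic carbon gives a modest step (a number 10.6 percentage points lower from compound 3 to compound 4 (beyond the scatter)), whereas every step among compound 1, compound 2 and compound 3 stayed within it. The separation holds only against compound 3, as the other two steps (a number 9.5 percentage points lower from compound 2 to compound 4 (within the scatter); a number 7.3 percentage points lower from compound 1 to compound 4 (within the scatter)) remain within the scatter, so hydroxymethyl is set apart from 3-hydroxypropyl but not from 3-fluorophenyl or heptyl. No measurement at hand offers a reason for this step.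

Two hydroxyalkyl chains cannot show whether the number follows chain length or whether hydroxymethyl alone stands apart. A 2-hydroxyethyl group, an aminomethyl group or a carboxylic acid in place of hydroxymethyl would test this.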